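Removing a Methyl on Two Different Fused Cores

The source may hold more compounds than are shown below. What is called first, only, known or untested is meant among the compounds shown, and "the series" means these compounds.

Compound 1 `Cc1nnc(S)n2cncc12` and compound 2 `Sc1nncc2cncn12` share one core. In a functional assay for inhibition, with Homo sapiens as the target (on this read-out higher numbers stand for weaker inhibition and lower numbers for stronger inhibition), compound 1 gives only a limit of the assay, > 48000 nM. Compound 2 likewise reaches only the limit in this assay, > 48000 nM. The change between them is hydrogen in place of methyl on an aromatic carbon, and the two limits leave its step unreadable: a step that the two limits leave unreadable from compound 1 to compound 2. Compound 3 `Cc1ncn2c(NCc3ccco3)nncc12` is built on another core; the difference between the two cores is not broken down here. In this assay compound 3 too gives only a limit, > 48000 nM. Compound 4 `c1coc(CNc2nncc3cncn23)c1` has not yet been measured and differs from compound 3 by hydrogen in place of methyl on an aromatic carbon. This is the same kind of change as that from compound 1 to compound 2, though its surroundings differ: in compound 1 the methyl sits on a six-membered aromatic ring with 3 nitrogen, ortho to a fused ring and para to a sulfanyl group, whereas in compound 3 it sits on a five-membered aromatic ring with 2 nitrogen. Because (the limit of > 48000 nM in this assay, at which 3 of the 3 values shown sit), the step expected here is a step that the limit leaves unreadable from compound 3 to compound 4. Compound 4 is therefore estimated at about 70000 nM, most likely reported again only as a limit, within 30000 nM to 250000 nM.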

Compound 4, half-maximal inhibitory concentration: > 48000 nM
Compound 4 gave a limit, no number (the forecaster's own chance of this, stated with the estimate: 85%); the middle value does not contradict the limit.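

The step between compound 3 and compound 4 cannot be read, because in this assay both compounds give only a limit: the limit of > 48000 nM in this assay, at which 4 of the 4 values shown sit.

The compounds shown leave open whether hydrogen in place of methyl on an aromatic carbon changes inhibition on either core, and how strongly, if at all, any of the four compounds inhibits.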